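Amide-to-urea exchange in a pyrazole series

The source may hold more compounds than are shown below. What is called first, only, known or untested is meant among the compounds shown, and "the series" means these compounds.

Measured so far:
compound 1, `COc1cc(-c2nn(-c3cccc(NC(=O)c4ccc(Cl)c(C(F)(F)F)c4)c3)cc2-c2ccncc2)ccc1Cl`, 1770 nM
compound 2, `O=C(Nc1cccc(-n2cc(-c3ccncc3)c(-c3ccc(Cl)c(O)c3)n2)c1)Nc1cc(C(F)(F)F)cc(C(F)(F)F)c1`, 789 nM

Compound 1 stands at the highest of the two numbers in a functional assay on CCRF-CEM cells (Homo sapiens) for inhibition, read by sulforhodamine B assay, with a stated time of 48 h; on this read-out higher numbers stand for weaker inhibition of growth and lower numbers for stronger inhibition of growth; its nearest neighbour, compound 2, gives 789 nM, a gap beyond the usual scatter. Among the measured compounds shown here, no pair of measured compounds differs in one place only, so no single step can be read directly.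

Compound 3, `COc1cc(-c2nn(-c3cccc(NC(=O)Nc4ccc(Cl)c(Cl)c4)c3)cc2-c2ccncc2)ccc1Cl`, is not yet measured. It differs from compound 1 at one place: (3,4-dichlorophenyl)amino in place of 4-chloro-3-(trifluoromethyl)phenyl on a carbonyl carbon. Compound 2 shares the same carbonyl flanked by two nitrogen atoms and gives the lower number of the pair; on that basis the step from compound 1 to compound 3 is expected to run toward stronger inhibition, by a 2.0-fold lower number from compound 1 to compound 3 (0.29 log units; within the scatter), somewhat beyond the scatter but modest. Compound 3 is therefore estimated at 900 nM, with a range from 350 nM to 2500 nM.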

Compound 3, concentration for 50% growth inhibition: 1040 nM
For compound 3 the middle estimate is 1.2-fold (0.06 log units) below the measured one; low and high end bracket the measured number.
By their numbers in this assay, from the lowest: compounds 2, 3 and 1 (each within the scatter of the next, the first and the last beyond it).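

In this assay, among the compounds shown here, (3,4-dichlorophenyl)amino in place of 4-chloro-3-(trifluoromethyl)phenyl on a carbonyl carbon gives a 1.7-fold lower number from compound 1 to compound 3 (0.23 log units; within the scatter), the first single-place comparison. At this position, then, the amide and the urea cannot be told apart on this read-out, at least for these two aryl groups. The exchange alters the atom on the carbonyl carbon and the ring substituents together, so the step cannot assign any share to either, and no supporting data bear on the result.

The compounds shown leave open how a urea carrying the 4-chloro-3-(trifluoromethyl)phenyl ring itself would read, which would separate the linking nitrogen from the ring substituents. Also open, as far as these compounds go, is whether a piperazine or a carboxylic acid on that ring would move the number beyond the scatter.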